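This account rests on a few compounds, and the source may have more. Where it says the series, first, only, none or still open, it means among the compounds named here.

In a functional assay on HepG2 cells (Homo sapiens) for antiproliferative activity, read by sulforhodamine B assay, with a stated time of 48 h (a higher number here means a weaker inhibitor, a lower number a stronger inhibitor), compound 1 `COc1ccc(/C=C/C(=O)c2ccccc2-c2ccc(OC)c(OC)c2)cc1OC` gives 3200 nM and compound 2 `COc1ccc(OC)c(/C=C/C(=O)c2ccccc2-c2ccc(OC)c(OC)c2)c1` gives 2100 nM. Compound 3 `COc1ccc(/C=C/C(=O)c2ccccc2-c2ccc(F)cc2)cc1` gives 93 nM, the lowest number of the three and beyond the scatter from both others. Compound 4 `COc1ccc(/C=C/C(=O)c2ccccc2-c2ccc(F)cc2)cc1B(O)O` differs from compound 3 in one place: a group of 3 heavy atoms (1 boron, 2 oxygen; no ring) in place of a hydrogen atom, on an aromatic carbon, ortho to a methoxy group and meta to a large group. Going by the values given here, the only measured single change, a 1.5-fold lower number from compound 1 to compound 2 (0.18 log units; within the scatter), lies within the scatter and concerns another part of the structure, so it offers only weak guidance. Among the compounds with values here, no measured compound carries the incoming group. The expected change in this assay is small and slightly upward, a 1.3-fold higher number from compound 3 to compound 4 (0.11 log units; within the scatter), though its direction is uncertain. For compound 4 the estimated value is 120 nM, with an expected range of 25 nM to 600 nM.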

Compound 4, half-maximal inhibitory concentration: 30 nM
The estimate for compound 4 lay 4.0-fold (0.60 log units) above the measured number, within the range that was stated.
By their numbers in this assay, from the lowest: compound 4; then compound 3; then compounds 2 and 1 (each within the scatter of the next).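

In this assay the group of 3 heavy atoms (1 boron, 2 oxygen), placed on the aromatic carbon ortho to a methoxy group where a hydrogen atom stood, gives a 3.1-fold lower number from compound 3 to compound 4 (0.49 log units; beyond the scatter) and so shows that this position can take the group with a modest improvement. Going by these compounds alone, none of the earlier compounds carries this group, so they could not show this. No measurement here explains the improvement. From the compounds shown here alone, whether an amine or a carboxylic acid on this carbon would do the same remains open, as does whether the boron group would lower the number on the core of compound 1.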